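Methoxy to hydroxy: compound 3 to compound 4

The source may hold more compounds than are shown below. What is called first, only, known or untested is meant among the compounds shown, and "the series" means these compounds.

Compound 1 `O=C(Nc1cccc(-n2cc(-c3ccncc3)c(-c3ccc(Cl)c(O)c3)n2)c1)Nc1cccc(C(F)(F)F)c1`, in a functional assay on SK-MEL-28 cells (Homo sapiens) for inhibition, read by sulforhodamine B assay, with a stated time of 48 h (a higher number here means a weaker inhibitor of growth, a lower number a stronger inhibitor of growth), a limit: > 32500 nM
Compound 2 `O=C(Nc1cccc(-n2cc(-c3ccncc3)c(-c3ccc(Cl)c(O)c3)n2)c1)Nc1ccc(Cl)c(Cl)c1`: 9850 nM
Compound 3 `COc1cc(-c2nn(-c3cccc(NC(=O)Nc4ccc(Cl)c(C(F)(F)F)c4)c3)cc2-c2ccncc2)ccc1Cl`: 5010 nM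

Compound 3 holds the lowest of the two numbers in this assay. Compound 2 at 9850 nM sits within the scatter of compound 3. Compound 1 gives only a limit. Compound 4 `O=C(Nc1cccc(-n2cc(-c3ccncc3)c(-c3ccc(Cl)c(O)c3)n2)c1)Nc1ccc(Cl)c(C(F)(F)F)c1` differs from compound 3 by hydrogen in place of methyl on an oxygen on an aromatic ring. Among the measured compounds shown here, the one measured step, an at least 3.2-fold lower number from compound 1 to compound 2 (0.51 log units; beyond the scatter), changes the group on the amide-type nitrogen, a different place, so no measured step bears on this methoxy-to-hydroxy change. With nothing to anchor a shift, compound 4 is expected to sit within the scatter of compound 3, a step of a 1.1-fold higher number from compound 3 to compound 4 (0.04 log units; within the scatter). Compound 4 is therefore estimated at 5500 nM, with a range of 1800 nM to 17000 nM.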

Compound 4, concentration for total growth inhibition: 3330 nM
For compound 4 the middle estimate is 1.7-fold (0.22 log units) above the measured one, within the range that was stated.
By their numbers in this assay, from the lowest: compounds 4, 3 and 2 (each within the scatter of the next, the first and the last beyond it). At a limit, above all of these: compound 1.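

In this assay the change from methoxy to hydroxy on an oxygen on an aromatic ring gives a 1.5-fold lower number from compound 3 to compound 4 (0.18 log units; within the scatter), so this step stays within the scatter. With the hydroxy kept, changes on an aromatic carbon go beyond it: trifluoromethyl in place of chloro gives a 3.0-fold lower number from compound 2 to compound 4 (0.47 log units; beyond the scatter), and chloro in place of hydrogen gives an at least 9.7-fold lower number from compound 1 to compound 4 (0.98 log units; beyond the scatter). Compound 1 stands at a limit and not at a number: the limit of > 32500 nM in this assay, at which 1 of the 4 values shown sits. The compounds shown leave open how an amine or a carboxylic acid in place of the hydroxy would read in this assay. From the compounds shown here alone, a longer chain on that oxygen, such as ethoxy, also remains open.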